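Chloro in place of nitro: cytotoxicity working notes

The source may report more compounds than this note shows. Statements on the series, on what has been measured and on what is new or still open speak of the compounds shown alone.

Of the compounds shown here, three have been measured in an ADME assay on HEL cells (Homo sapiens) for cytotoxicity; a lower number here means that less compound is tolerated, a higher number that more compound is tolerated. Compound 3 `O=C(COc1cccc2ccccc12)N/N=C/c1ccc([N+](=O)[O-])cc1` gives 14.2 ug/mL. Compound 1 `O=C(COc1cccc2ccccc12)N/N=C/c1ccc(Cl)cc1` gives 100 ug/mL. Compound 2 `C/C(=N\NC(=O)COc1cccc2ccccc12)c1ccc([N+](=O)[O-])cc1` gives only a limit, > 100 ug/mL, so no number is known for it. How the core of compound 2 differs from the core of compound 3 is not broken down here.

Going by the values given here, the one counted step between measured compounds is a 7.0-fold higher number from compound 3 to compound 1 (0.85 log units; beyond the scatter), and the change behind it is chloro in place of nitro on an aromatic carbon. Compound 4 `C/C(=N\NC(=O)COc1cccc2ccccc12)c1ccc(Cl)cc1` has not yet been measured in this assay; it is reached from compound 2 by chloro in place of nitro on an aromatic carbon. The place is described in the same words for both pairs, so this is the same change, made twice among the four compounds shown.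

The expected step for the unmeasured pair is a step that the limit leaves unreadable from compound 2 to compound 4, set beside the measured step of a 7.0-fold higher number from compound 3 to compound 1 (0.85 log units; beyond the scatter); the expectation rests on that single measured step and on nothing else in the data. Because compound 2 already sits at the limit (the limit of > 100 ug/mL in this assay, at which 1 of the 3 values shown sits), the read-out for compound 4 is expected to come back as a limit rather than as a number. Compound 4 is estimated at 250 ug/mL, with a range from 80 ug/mL to 800 ug/mL.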

Compound 4, half-maximal cytotoxic concentration in the HEL assay: 7.1 ug/mL
Compound 4: the middle estimate sits 35-fold (1.55 log units) above what was measured; measured number below the stated range.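

In the HEL assay the new step is an at least 14-fold lower number from compound 2 to compound 4 (1.14 log units; beyond the scatter), which runs opposite to a 7.0-fold higher number from compound 3 to compound 1 (0.85 log units; beyond the scatter), so chloro in place of nitro on an aromatic carbon does not carry from one core to the other among these four compounds. Set side by side, the two steps disagree by more than repeated measurement would explain, and the step on one core gives no guide to the step on the other: the same change on two cores in the HEL assay, a 7.0-fold higher number (0.85 log units; beyond the scatter) from compound 3 to compound 1 and an at least 14-fold lower number (1.14 log units; beyond the scatter) from compound 2 to compound 4, at least 99-fold (1.99 log units) apart, beyond the scatter of two such steps. In a physicochemical assay for lipophilicity, measured as octanol-water partition (a higher number here means a more lipophilic compound, a lower number a more polar compound), compound 2 gives 3.37 and compound 4 gives 4.17. What this does not show is why the two cores part, and the rise in partition coefficient on the core of compound 2 cannot settle that, as it is given for this one pair only: the measured partition coefficient of compound 2, 3.37, and of compound 4, 4.17, a number 0.80 log units higher (beyond the scatter).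

In the HEL assay compound 2 remains a limit, > 100 ug/mL, which leaves the full size of its step open. Also open, going by these compounds, is how an amine or a carboxylic acid at the same place on the aromatic ring would behave on either core, and two pairs are too few to support a rule for the series.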